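Nitro in Place of Trifluoromethyl at the Assay Limit

A few compounds are considered here, and "the series" means these few. Any claim that something is new, unique, unknown or untested is made for them only; others in the source may bear on it.

Measured compounds:
compound 1 `FC(F)(F)c1ccc(COc2ccccc2Nc2ncnc3cc4c(cc23)OCCOCCOCCO4)cc1` — > 100000 nM
compound 2 `FC(F)(F)c1ccc(COc2ccccc2Nc2ncnc3cc4c(cc23)OCCOCCO4)cc1` — > 100000 nM
compound 3 `O=[N+]([O-])c1ccc(COc2ccccc2Nc2ncnc3cc4c(cc23)OCCOCCO4)cc1` — 50200 nM

In a functional assay on HepG2 cells (Homo sapiens) for antiproliferative activity, read by MTT assay, with a stated time of 72 h (a lower number here means a stronger inhibitor, a higher number a weaker inhibitor), compound 1 gives only a limit, > 100000 nM. Compound 2 likewise reaches no number in this assay and stands at the limit > 100000 nM. Going by the values given here, compound 3 is the one compound with a measured number in this assay, giving 50200 nM. The difference between the cores of compound 1 and compound 2 is not broken down here. Compound 2 and compound 3 differ only by nitro in place of trifluoromethyl on an aromatic carbon, and that change produces an at least 1.9-fold lower number from compound 2 to compound 3 (0.29 log units; that floor lies within the scatter), a floor set by the limit of > 100000 nM in this assay, at which 2 of the 3 values shown sit.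

Compound 4 `O=[N+]([O-])c1ccc(COc2ccccc2Nc2ncnc3cc4c(cc23)OCCOCCOCCO4)cc1` has not been measured. It relates to compound 1 exactly as compound 3 relates to compound 2, the change being (nitro in place of trifluoromethyl on an aromatic carbon). The change is the same kind of change at the same place on the outer aromatic ring. Compound 4 is expected to move by about an at least 1.6-fold lower number from compound 1 to compound 4 (0.22 log units; that floor lies within the scatter). That expectation rests on the floor an at least 1.9-fold lower number from compound 2 to compound 3 (0.29 log units; that floor lies within the scatter), which itself lies within the scatter. Compound 4 is therefore estimated at 60000 nM, between 25000 nM and 200000 nM, with a real chance that only a limit is reported.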

Compound 4, half-maximal inhibitory concentration: 60800 nM
Compound 4: the middle estimate sits 1.0-fold (0.01 log units) below what was measured, within the range that was stated.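

Carried to the core of compound 1, nitro in place of trifluoromethyl gives an at least 1.6-fold lower number from compound 1 to compound 4 (0.21 log units; that floor lies within the scatter) in this assay, and on both cores the nitro compound reaches a measured number while the trifluoromethyl compound stays at a limit: the same change on two cores in this assay, an at least 1.9-fold lower number (0.29 log units; that floor lies within the scatter) from compound 2 to compound 3 and an at least 1.6-fold lower number (0.21 log units; that floor lies within the scatter) from compound 1 to compound 4; the limit leaves it open whether they differ

This shows that the same outcome appears on the two cores, and the claim reaches no further than these two pairs. It does not give the true size of the change on either core, nor show that a size carries from one core to the other, since each step is only a floor and the trifluoromethyl compounds supply no number: the limit of > 100000 nM in this assay, at which 2 of the 4 values shown sit.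

The compounds shown leave open how other groups in the same place, such as a nitrile, an amine or a carboxylic acid, would read in this assay. They also leave open whether a longer chain in the core than that of compound 4 would change the reading.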